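A few compounds are considered here, and "the series" means these few. Any claim that something is new, unique, unknown or untested is made for them only; others in the source may bear on it.

Compound 1 `CS(=O)(=O)Nc1cccc(Nc2nccc(Nc3ccc4nc[nH]c4c3)n2)c1`: > 25000 nM, a limit of the assay and not a number
Compound 2 `Cc1cccc(Nc2nccc(Nc3ccc4nc[nH]c4c3)n2)c1`: 20000 nM

Within the data shown here, in an ADME assay on HepG2 cells (Homo sapiens) for inhibition, read by fluorescence and resazurin assay, with a stated time of 72 h (a higher number here means a weaker inhibitor, a lower number a stronger inhibitor), compound 2 gives 20000 nM, the only actual number available so far. Compound 1 stands at the limit of > 25000 nM in this assay, at which 1 of the 2 values shown sits.

The next molecule is compound 3 `CN1CCN(c2cccc(Nc3nccc(Nc4ccc5nc[nH]c5c4)n3)c2)CC1`. It carries 4-methylpiperazin-1-yl in place of methyl on an aromatic carbon, meta to a large group: 4-methylpiperazin-1-yl in place of methyl on an aromatic carbon.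

Among the measured compounds shown here, only one measured step bears on this change, the swap of methanesulfonamido for methyl on an aromatic carbon: an at least 1.2-fold lower number from compound 1 to compound 2 (0.09 log units; that floor lies within the scatter). That step is only a floor, and it involves a different incoming group, so it offers weak guidance for compound 3. With so little to go on, a small move towards a lower number is expected, though the true result may well stay within the scatter of compound 2, or reach the limit of the assay.

The expected step is a 2.0-fold lower number from compound 2 to compound 3 (0.30 log units; within the scatter). For compound 3 the estimated value is 10000 nM, with an expected range from 2500 nM to 25000 nM.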

Compound 3, half-maximal inhibitory concentration: 11000 nM
The estimate for compound 3 lay 1.1-fold (0.04 log units) below the measured number; low and high end bracket the measured number.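

This result shows that the aromatic carbon carrying these groups, meta to a large group, tolerates a sizeable increase in bulk in this assay: 4-methylpiperazin-1-yl brings 7 heavy atoms and a six-membered non-aromatic ring where methyl has 1 heavy atom, yet the step is a 1.8-fold lower number from compound 2 to compound 3 (0.26 log units; within the scatter), so compound 2 and compound 3 cannot be told apart. Comparing the same group with methanesulfonamido gives the first step in this series that lies beyond the scatter: an at least 2.2-fold lower number from compound 1 to compound 3 (0.35 log units; beyond the scatter). Its true size stays unknown, since compound 1 is a limit of the assay and not a number: the limit of > 25000 nM in this assay, at which 1 of the 3 values shown sits.

The compounds shown leave open how far the methanesulfonamido group really lies from the other two, and whether any group on this carbon can move the number well beyond the scatter of compound 2. A simple primary amine, a carboxylic acid or a longer chain ending in an amine would test this, and changes elsewhere on the shared core remain a separate question.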